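Trimming the ring-nitrogen substituent of a purine-like nucleoside

This account rests on a few compounds, and the source may have more. Where it says the series, first, only, none or still open, it means among the compounds named here.

Measured compounds:
Compound 1, `COc1ccc(Cn2c(=O)n(C3OC(CO)[C@@H](O)[C@H]3O)c3nc(N)nc(O)c32)cc1`, 14%
Compound 2, `CCCn1c(=O)n(C2C=CC(CO)O2)c2nc(N)nc(O)c21`, 84%

Of the compounds shown here, two share a core and have been tested in a functional assay on the whole organism with Mus musculus as the target; a lower number here means a smaller maximal response, a higher number a larger maximal response. Compound 1 gives 14%, the lowest of the two numbers, and compound 2 gives 84%, a higher number, a gap beyond the usual scatter. The two differ in more than one place, so their values are set side by side without a step between them.

Compound 3, `Cn1c(=O)n(C2OC(CO)[C@@H](O)[C@H]2O)c2nc(N)nc(O)c21`, has not yet been measured. It differs from compound 1 in this way: hydrogen in place of 4-methoxyphenyl on a saturated chain carbon bound to an aromatic nitrogen.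

Compound 1 carries the larger group and stands low. Compound 2, which carries a shorter chain on the same nitrogen, though with a different sugar, stands high. On that basis a sizeable increase in this assay is expected for compound 3, with the step of a number 41 percentage points higher from compound 1 to compound 3 (beyond the scatter). For the measured compounds named here, the estimate for compound 3 is 55%, with a range from 25% to 85%, the wide range reflecting that no single-change step is known.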

Compound 3, largest response reached (reported as maximal response), in percent of the reference or control that the assay uses: 100%
Estimate against measurement, compound 3: 45 percentage points below; the measured number lies above the stated range.
By their numbers in this assay, from the lowest: compound 1; then compound 2; then compound 3.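

For the compounds shown here, with the sugar held constant, the change from 4-methoxybenzyl to methyl gives the first single-place comparison at this ring nitrogen, and in this assay it reads a number 86 percentage points higher from compound 1 to compound 3 (beyond the scatter). The substituent on this nitrogen can therefore by itself separate a low maximal response from a high one, with no change in the sugar needed, and the smaller methyl group is the one that goes with the high number in this pair. Nothing measured here explains why the response changes in this way.

With this sugar, the compounds shown mark only two points, methyl and 4-methoxybenzyl, so it remains open whether the response falls gradually or abruptly as the group grows, and an ethyl group, a longer chain such as n-butyl, or an unsubstituted benzyl group would help to place that drop. As far as these compounds go, it also remains open whether the loss follows from the benzene ring itself or from its methoxy group, and how an amine or a carboxylic acid at the end of a chain on this nitrogen would read in this assay.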